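Compound 3 to compound 4: benzyl swapped for propyl

A few compounds are considered here, and "the series" means these few. Any claim that something is new, unique, unknown or untested is made for them only; others in the source may bear on it.

Values in a functional assay on MGC-803 cells (Homo sapiens) for inhibition, read by MTT assay, with a stated time of 72 h (on this read-out lower numbers stand for stronger inhibition and higher numbers for weaker inhibition), so far:
- compound 1 `Cc1cc(Nc2cc(-c3ccccc3)[nH]n2)n2nc(SCc3c(Cl)cccc3Cl)nc2n1` gives 5280 nM
- compound 2 `Cc1cc(Nc2cc(-c3ccccc3)[nH]n2)n2nc(SCc3ccc([N+](=O)[O-])cc3)nc2n1` gives 4250 nM
- compound 3 `Cc1ccc(CSc2nc3nc(C)cc(Nc4cc(-c5ccccc5)[nH]n4)n3n2)cc1` gives 6960 nM

Compound 3 stands level with the other two, as a 1.3-fold higher number from compound 1 to compound 3 (0.12 log units; within the scatter) and a 1.6-fold higher number from compound 2 to compound 3 (0.21 log units; within the scatter) show. The next change leads to compound 4 `CCCSc1nc2nc(C)cc(Nc3cc(-c4ccccc4)[nH]n3)n2n1` and reads ethyl in place of 4-methylphenyl on a saturated chain carbon bound to a sulfur in short, ethyl in place of 4-methylphenyl on a saturated chain carbon bound to a sulfur. The third measured step, a 1.2-fold lower number from compound 1 to compound 2 (0.09 log units; within the scatter) likewise, exchanges one phenyl group for another. Among the compounds with values here, no measured step removes the aromatic ring, so the evidence is thin. No shift beyond the scatter is expected in this assay and the expected step is a 1.1-fold lower number from compound 3 to compound 4 (0.03 log units; within the scatter) with wide uncertainty. For compound 4 the estimate is 6500 nM with an expected range of 2500 nM to 17000 nM in this read-out.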

Compound 4, half-maximal inhibitory concentration: 12600 nM
Compound 4: the middle estimate sits 1.9-fold (0.29 log units) below what was measured; low and high end bracket the measured number.
By their numbers in this assay, from the lowest: compounds 2, 1, 3 and 4 (each within the scatter of the next, the first and the last beyond it).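

Taking the aromatic ring off this saturated chain carbon bound to a sulfur gives the first shifts beyond the scatter in the series, and they are modest (a 3.0-fold higher number from compound 2 to compound 4 (0.47 log units; beyond the scatter)) and (a 2.4-fold higher number from compound 1 to compound 4 (0.38 log units; beyond the scatter)) in this assay. The remaining step stays within the scatter (a 1.8-fold higher number from compound 3 to compound 4 (0.26 log units; within the scatter)), so the ring is not needed for a measurable read-out and the propyl compound gives up little. No supporting evidence bears on this shift.

Still open, going by these compounds, is whether the ring or simply the size of the group matters here. A longer chain such as hexyl, or an amine or a carboxylic acid at the chain end, would test this.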